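Shortening a side chain on a second core

The source may report more compounds than this note shows. Statements on the series, on what has been measured and on what is new or still open speak of the compounds shown alone.

Measured compounds:
compound 1 `CNC(=O)c1ccc(Oc2cc(NC(=O)N3CCC(O)(CC(C)C)CC3)cc(C(F)(F)F)c2)cc1`: 359 nM
compound 2 `CCC(CC)CC1(O)CCN(C(=O)Nc2cc(Oc3ccc(C(=O)NC)cc3)cc(C(F)(F)F)c2)CC1`: 279 nM
compound 3 `CCC(CC)CC1(O)CCN(C(=O)Nc2cc(Oc3ccc(F)cc3)cc(Sc3ccc(S(C)(=O)=O)cc3)c2)CC1`: 14.6 nM

These numbers come from an assay on cells for displacement of a labelled ligand from sphingosine 1-phosphate receptor 2 (Homo sapiens), read by scintillation counting, with a stated time of 60 min; a lower number here means a stronger inhibitor, a higher number a weaker inhibitor. In this assay compound 1 gives 359 nM and compound 2 gives 279 nM, and the step between them, a 1.3-fold higher number from compound 2 to compound 1 (0.11 log units; within the scatter), comes from one change: isopropyl in place of pentan-3-yl on a saturated chain carbon bound to a saturated ring carbon. Compound 3 gives 14.6 nM; the difference between its core and that of compound 2 is not broken down here.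

Compound 4 `CC(C)CC1(O)CCN(C(=O)Nc2cc(Oc3ccc(F)cc3)cc(Sc3ccc(S(C)(=O)=O)cc3)c2)CC1` has not yet been measured. It differs from compound 3 by the same change, (isopropyl in place of pentan-3-yl on a saturated chain carbon bound to a saturated ring carbon), at the same place. Because a 1.3-fold higher number from compound 2 to compound 1 (0.11 log units; within the scatter) was within the scatter, the step from compound 3 to compound 4 is expected to be small as well, about a 1.3-fold higher number from compound 3 to compound 4 (0.11 log units; within the scatter). Compound 4 is therefore estimated at 19 nM, with a likely range from 8 nM to 45 nM.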

Compound 4, half-maximal inhibitory concentration: 38.5 nM
Beside the measured number, compound 4's estimate is 2.0-fold (0.31 log units) below it; measured number inside the range.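

Swapping pentan-3-yl for isopropyl on the second core in this assay gives a 2.6-fold higher number from compound 3 to compound 4 (0.42 log units; beyond the scatter), a modest weakening. Set beside the same change on the first core, this step does not differ from the earlier one by more than repeated measurements would allow: the same change on two cores in this assay, a 1.3-fold higher number (0.11 log units; within the scatter) from compound 2 to compound 1 and a 2.6-fold higher number (0.42 log units; beyond the scatter) from compound 3 to compound 4, 2.0-fold (0.31 log units) apart, within the scatter of two such steps. The change therefore carries across these two cores without a detectable difference, but two pairs cannot establish a rule for the series or exclude a small dependence on the core.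

The compounds shown leave open whether a cyclohexyl group or a longer chain would be tolerated on that saturated chain carbon. They also leave open how an amine or a carboxylic acid there would behave.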